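From Nitro to Propoxy on a Shared Core

A few compounds are considered here, and "the series" means these few. Any claim that something is new, unique, unknown or untested is made for them only; others in the source may bear on it.

Compound 1 `CCC(CO)Nc1nc(NCc2ccccc2)c2nc(Cl)n(C(C)C)c2n1`: 54000 nM
Compound 2 `CCC(CO)Nc1nc(NCc2ccccc2)c2nc(S)n(C(C)C)c2n1`: 55000 nM
Compound 3 `CCC(CO)Nc1nc(NCc2ccccc2)c2nc([N+](=O)[O-])n(C(C)C)c2n1`: 117000 nM

All three values come from a functional assay on MCF7 cells (Homo sapiens) for cytotoxicity; a lower number here means a stronger inhibitor, a higher number a weaker inhibitor. Compound 3 has the highest number of the three, which makes it the weakest inhibitor of the set, though only by a modest margin. Compound 4 `CCCOc1nc2c(NCc3ccccc3)nc(NC(CC)CO)nc2n1C(C)C` keeps the shared core and carries propoxy in place of nitro on an aromatic carbon, (propoxy in place of nitro on an aromatic carbon). This carbon lies between two ring nitrogen atoms, next to the ring atom that bears an isopropyl group.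

All three measured steps change this same place. Exchanging chloro for sulfanyl gave a 1.0-fold higher number from compound 1 to compound 2 (0.01 log units; within the scatter), so these two compounds cannot be told apart. Nitro stands apart from both, with a 2.2-fold higher number from compound 1 to compound 3 (0.34 log units; beyond the scatter) and a 2.1-fold higher number from compound 2 to compound 3 (0.33 log units; beyond the scatter). Going by the values given here, no propoxy compound has been measured, so these steps offer only indirect guidance. Removing nitro may bring the number back toward the level of compound 2 at 55000 nM, but the range must stay wide. The expected result is a modest decrease, a 1.7-fold lower number from compound 3 to compound 4 (0.22 log units; within the scatter), which may not clear the scatter. Compound 4 is estimated at 70000 nM, with an expected range from 30000 nM to 150000 nM.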

Compound 4, half-maximal inhibitory concentration: 50000 nM
Beside the measured number, compound 4's estimate is 1.4-fold (0.15 log units) above it; the range from low to high includes it.
By their numbers in this assay, from the lowest: compounds 4, 1 and 2 (each within the scatter of the next); then compound 3.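

In this assay, the exchange of nitro for propoxy gave a 2.3-fold lower number from compound 3 to compound 4 (0.37 log units; beyond the scatter), which shows that the higher number of compound 3 is tied to nitro and that a group entering through an oxygen atom at this carbon does not carry it. Propoxy also falls level with the two earlier groups, with a 1.1-fold lower number from compound 2 to compound 4 (0.04 log units; within the scatter) and a 1.1-fold lower number from compound 1 to compound 4 (0.03 log units; within the scatter), so chloro, sulfanyl and propoxy cannot be told apart here, and among these four compounds nitro is the only group that stands apart, leaving compound 3 as the weakest inhibitor of the set. Nothing available explains why nitro stands apart from the other three groups at this position.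

The compounds shown leave open whether the length of the chain matters on this aromatic carbon, a question that a methoxy or a butoxy group would address. They also leave open whether an amine or a carboxylic acid at the same carbon would join chloro, sulfanyl and propoxy, stand apart as nitro does, or move the number clearly below that level.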